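Removing a second acetyl group from a macrolide series

A few compounds are considered here, and "the series" means these few. Any claim that something is new, unique, unknown or untested is made for them only; others in the source may bear on it.

Among the compounds with values here, compound 2 `C=C/C=C\[C@H](C)[C@H](OC(N)=O)[C@@H](C)[C@H](O)[C@@H](C)C/C(C)=C\[C@H](C)[C@@H](OC(C)=O)[C@@H](C)/C=C\[C@H](C[C@@H]1OC(=O)[C@H](C)[C@@H](OC(C)=O)[C@H]1C)OC(C)=O` stands lowest of the two numbers measured so far: in a functional assay on P388 cells (Mus musculus) for cytotoxicity, read by MTT assay, with a stated time of 48 h (a higher number here means a weaker inhibitor, a lower number a stronger inhibitor), compound 2 gives 166 nM, whereas compound 1 `C=C/C=C\[C@H](C)[C@H](OC(N)=O)[C@@H](C)[C@H](OC(C)=O)[C@@H](C)C/C(C)=C\[C@H](C)[C@@H](OC(C)=O)[C@@H](C)/C=C\[C@H](C[C@@H]1OC(=O)[C@H](C)[C@@H](OC(C)=O)[C@H]1C)OC(C)=O` gives 837 nM. Within the data shown here, the one measured step, a 5.0-fold lower number from compound 1 to compound 2 (0.70 log units; beyond the scatter), came from the same kind of change at another site. Compound 3 `C=C/C=C\[C@H](C)[C@H](OC(N)=O)[C@@H](C)[C@H](O)[C@@H](C)C/C(C)=C\[C@H](C)[C@@H](OC(C)=O)[C@@H](C)/C=C\[C@@H](O)C[C@@H]1OC(=O)[C@H](C)[C@@H](OC(C)=O)[C@H]1C` differs from compound 2 in one place: hydrogen in place of acetyl on an oxygen on a saturated carbon. A further lowering is expected because a 5.0-fold lower number from compound 1 to compound 2 (0.70 log units; beyond the scatter) followed the same type of change, though at a different site it need not repeat, so a modest step of a 1.8-fold lower number from compound 2 to compound 3 (0.27 log units; within the scatter) is expected. Compound 3 is therefore estimated at 90 nM, with a range from 25 nM to 400 nM.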

Compound 3, half-maximal inhibitory concentration: 103 nM
Estimate against measurement, compound 3: 1.1-fold (0.06 log units) below, within the range that was stated.
By their numbers in this assay, from the lowest: compounds 3 and 2 (each within the scatter of the next); then compound 1.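

In this assay the change from acetoxy to hydroxy at this site gives a 1.6-fold lower number from compound 2 to compound 3 (0.21 log units; within the scatter) and so cannot be told from repeat-measurement noise, whereas the same change at the other site gave a 5.0-fold lower number from compound 1 to compound 2 (0.70 log units; beyond the scatter) and could. The effect of removing an acetyl group in this pair of steps therefore depends on the site. Nothing available here accounts for that difference between the two sites. As far as these compounds go, whether a methyl ether or an amine at this oxygen-bearing carbon would shift the number remains open. So does the effect of removing the acetyl groups still present in compound 3.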